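The source may report more compounds than this note shows. Statements on the series, on what has been measured and on what is new or still open speak of the compounds shown alone.

Compound 2 `N/C(=N\O)c1ccc(C2=C(S(=O)(=O)c3ccc(Nc4cccc(/C(N)=N/O)c4)cc3)CC(c3ccccc3)(c3ccccc3)O2)cc1` stands at a limit in an ADME assay on THP-1 cells (Homo sapiens) for cytotoxicity, read by flow cytometry, with a stated time of 72 h; on this read-out lower numbers stand for stronger inhibition and higher numbers for weaker inhibition: compound 2 gives > 50000 nM, a limit of > 50000 nM in this assay, at which 1 of the 2 values shown sits, and not a number. Compound 1 `N/C(=N\O)c1ccc(C2=C(S(=O)(=O)c3ccccc3)CC(c3ccccc3)(c3ccccc3)O2)cc1` gives 30600 nM in this assay, and an at least 1.6-fold higher number from compound 1 to compound 2 (0.21 log units; that floor lies within the scatter). Compound 3 `N/C(=N\O)c1ccc(/C=C/c2ccc(S(=O)(=O)C3=C(c4ccc(/C(N)=N/O)cc4)OC(c4ccccc4)(c4ccccc4)C3)cc2)cc1` differs from compound 2 by a group of 12 heavy atoms (9 carbon, 2 nitrogen, 1 oxygen; one six-membered aromatic ring of carbon only) in place of a group of 11 heavy atoms (7 carbon, 3 nitrogen, 1 oxygen; one six-membered aromatic ring of carbon only), on an aromatic carbon. Going by the values given here, only the step from compound 1 to compound 2 bears on this change, and it stays within the scatter, so for compound 3 no step beyond the scatter is expected in this assay, with the limit a live possibility. The estimate for compound 3 is 50000 nM (range 20000 nM to 150000 nM), an expected step of a number no higher from compound 2 to compound 3 (the limit leaves the size open).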

Compound 3, half-maximal inhibitory concentration: > 10000 nM
Compound 3: only a limit was reported; the forecaster's own chance of this, stated with the estimate: 60%; the middle value does not contradict the limit.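

Compound 3 gives > 10000 nM in this assay, a limit and not a number, so its steps from compound 1 and compound 2 cannot be read. Where compound 3 truly stands relative to compound 1 and compound 2 stays open.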